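The source may hold more compounds than are shown below. What is called first, only, known or untested is meant among the compounds shown, and "the series" means these compounds.

In a functional assay on A498 cells (Homo sapiens) for inhibition, read by sulforhodamine B assay, with a stated time of 48 h (on this read-out lower numbers stand for stronger inhibition of growth and higher numbers for weaker inhibition of growth), compound 1 `Cc1ccc(C2=NN(c3ccc(S(C)(=O)=O)cc3)C(=O)CC2)cc1` gives 1600 nM, while compound 2 `Cc1cc(O)ccc1C1=NN(c2ccc(S(C)(=O)=O)cc2)C(=O)CC1` gives 45400 nM, the higher of the two numbers. Going by the values given here, the only measured step, a 28-fold higher number from compound 1 to compound 2 (1.45 log units; beyond the scatter), is large and beyond the scatter, and it replaces 4-methylphenyl with 4-hydroxy-2-methylphenyl. Compound 3 `CCc1ccc(C2=NN(c3ccc(S(C)(=O)=O)cc3)C(=O)CC2)cc1` reverses most of that change, with 4-ethylphenyl in place of 4-hydroxy-2-methylphenyl on a carbon with a double bond to nitrogen. Its closest measured relative is therefore compound 1 at 1600 nM, so a large drop of similar size is expected. The expected change is a 23-fold lower number from compound 2 to compound 3 (1.36 log units; beyond the scatter). For compound 3 the estimated value is 2000 nM, with an expected range of 700 nM to 6000 nM.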

Compound 3, concentration for total growth inhibition: 2300 nM
Compound 3: middle estimate off by 1.2-fold (0.06 log units), on the low side; the range from low to high includes it.
By their numbers in this assay, from the lowest: compounds 1 and 3 (each within the scatter of the next); then compound 2.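

In this assay, the chain on the 4-position phenyl can change from methyl to ethyl with only a 1.4-fold higher number from compound 1 to compound 3 (0.16 log units; within the scatter), so this position holds 4-ethylphenyl as well as 4-methylphenyl. The step of a 20-fold lower number from compound 2 to compound 3 (1.30 log units; beyond the scatter) shows that the high number of compound 2 belongs to its 4-hydroxy-2-methylphenyl group, not to the shared core. No measurement here explains either step. The compounds shown leave open whether the hydroxyl or the extra ring methyl accounts for the loss in compound 2. They also leave open how a propyl chain or an amine would read at this position.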